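The compounds below may be only part of what the source reports. "The series", "measured", "known", "first", "only" and "open" are said of these compounds alone.

Of the compounds shown here, three have been measured in a functional assay on the whole organism (strain Hartley) for inhibition, with Cavia porcellus as the target, with stated times of 15 min and 2 min; a lower number here means that less compound is needed, a higher number that more compound is needed for the effect. Compound 1 (`CCCCC1([C@@H](O)/C=C/C2[C@H](O)CC(=O)[C@@H]2CCCCCCC(=O)O)CCC1`) gives 0.03 mg/kg, the highest of the three numbers. Compound 2 (`CCCCC1([C@@H](O)/C=C/C2CCC(=O)[C@@H]2CCCCCCC(=O)OCC)CCC1`) gives 0.00206 mg/kg, and compound 3 (`CCCC1([C@H](O)/C=C/C2[C@H](O)CC(=O)[C@@H]2C/C=C\CCCC(=O)O)CCC1`) gives 0.003 mg/kg. Both lie well below compound 1, beyond the usual scatter, and are close to each other.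

The next compound to be tested, compound 4 (`CCCCC1([C@H](O)/C=C/C2[C@H](O)CC(=O)[C@@H]2CCCCCCC(=O)O)CCC1`), differs from compound 1 only in its stereochemistry: the two compounds have the same atoms and bonds; at least one stereo element is drawn with a configuration in one of them and without one in the other: 1 of 5 stereo elements differ; a stereocentre at a saturated chain carbon is drawn S in compound 1 and R in compound 4. Its atoms and bonds are the same, and a stereocentre at a saturated chain carbon is drawn S in compound 1 and R in compound 4.

For the measured compounds named here, no measured pair isolates a change of this kind, so the size of the step in this assay cannot be read directly from the data. A moderate move towards a lower number is expected, since compound 1 at 0.03 mg/kg sits at the top of the measured range. The estimated change is a 3.0-fold lower number from compound 1 to compound 4 (0.48 log units; beyond the scatter). For compound 4 the expected value is 0.01 mg/kg, within an estimated range of 0.002 mg/kg to 0.06 mg/kg.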

Compound 4, dose for half-maximal effect: 0.00145 mg/kg
The estimate for compound 4 lay 6.9-fold (0.84 log units) above the measured number; the measured number lies below the stated range.
By their numbers in this assay, from the lowest: compounds 4, 2 and 3 (each within the scatter of the next, the first and the last beyond it); then compound 1.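

Changing one stereocentre at a saturated chain carbon, drawn S and then R, gives in this assay a 21-fold lower number from compound 1 to compound 4 (1.32 log units; beyond the scatter), a large step beyond the scatter, while the atoms and bonds stay the same. For the compounds shown here, this is the first measured pair that isolates a single change, and it shows that the configuration drawn at this chain carbon can by itself go with a large shift in the dose needed. The step should be read with one qualification: the fact that one of compounds 1 and 4 is drawn with a defined configuration and the other without, at the place where they differ

The compounds shown leave open whether the same stereochemical change gives a step of this size when the rest of the molecule differs, as with the ethyl ester of compound 2. Also open, going by these compounds, is what a methyl group or a fluorine atom on this chain carbon would do to the number.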